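A few compounds are considered here, and "the series" means these few. Any claim that something is new, unique, unknown or untested is made for them only; others in the source may bear on it.

Measured compounds:
compound 1 `CO[C@H]1CC[C@H](Nc2cc(NCc3cnccc3C(F)(F)F)ncc2C#N)CC1` — 1100 nM
compound 2 `CC1(C)C[C@H](Nc2cc(NCc3cnccc3C(F)(F)F)ncc2C#N)CC(C)(C)[C@@H]1O` — 12 nM

In an assay on isolated protein for inhibition of protein kinase C theta type (Homo sapiens), read by TR-FRET, with a stated time of 2 h (on this read-out lower numbers stand for stronger inhibition and higher numbers for weaker inhibition), compound 1 stands at the highest of the two numbers, with 1100 nM; compound 2 gives 12 nM, a far lower number that lies well beyond the scatter. Compound 3 `CC1(C)C[C@H](Nc2cc(NCc3cnccc3C(F)(F)F)ncc2C#N)CC[C@@H]1O` carries the change (4-hydroxy-3,3-dimethylcyclohexyl in place of 4-methoxycyclohexyl on a nitrogen on an aromatic ring). Among the compounds with values here, no measured pair isolates this change, so the gap between compound 1 and compound 2 is the only guide. On that basis the expected step of an 18-fold lower number from compound 1 to compound 3 (1.26 log units; beyond the scatter) runs toward a lower number. Compound 3 is therefore estimated at 60 nM, with a likely range from 15 nM to 250 nM in this assay.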

Compound 3, half-maximal inhibitory concentration: 7 nM
The estimate for compound 3 lay 8.6-fold (0.93 log units) above the measured number; measured number below the stated range.
By their numbers in this assay, from the lowest: compounds 3 and 2 (each within the scatter of the next); then compound 1.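

On the nitrogen on an aromatic ring, 4-hydroxy-3,3-dimethylcyclohexyl in place of 4-methoxycyclohexyl gives, in this assay, a 160-fold lower number from compound 1 to compound 3 (2.20 log units; beyond the scatter), showing that this position answers strongly to a single change. Compound 3 at 7 nM and compound 2 at 12 nM lie within the scatter of each other, and the further methyl groups on the ring of compound 2 shift the number by no readable amount. No measurement given here bears on the cause of the step. Going by these compounds, the hydroxy group and the methyl groups arrive together, and it remains open which of them carries the step. Also open, on these data alone, is where a cyclohexyl ring with the hydroxy group alone, or with an amine in its place, would stand.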